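Swapping the triazole substituent in a flavanone series

A few compounds are considered here, and "the series" means these few. Any claim that something is new, unique, unknown or untested is made for them only; others in the source may bear on it.

Measured so far:
Compound 1, `COc1ccc([C@@H]2CC(=O)c3c(O)cc(OCc4cn(C5CCCC5)nn4)cc3O2)cc1O`: 10500 nM
Compound 2, `COc1ccc([C@@H]2CC(=O)c3c(O)cc(OCc4cn(Cc5ccccc5)nn4)cc3O2)cc1O`: 11000 nM
Compound 3, `COc1ccc([C@@H]2CC(=O)c3c(O)cc(OCc4cn(Cc5ccccc5F)nn4)cc3O2)cc1O`: 7320 nM

In a functional assay on RAW264.7 cells (Mus musculus) for inhibition, read by Griess assay, with stated times of 2 h and 24 h (a lower number here means a stronger inhibitor, a higher number a weaker inhibitor), the three numbers sit close together. Compound 2 cannot be set apart from its neighbours, since the steps of a 1.0-fold higher number from compound 1 to compound 2 (0.02 log units; within the scatter) and a 1.5-fold lower number from compound 2 to compound 3 (0.18 log units; within the scatter) are both within the scatter, as is a 1.4-fold lower number from compound 1 to compound 3 (0.16 log units; within the scatter). Compound 4, `COc1ccc([C@@H]2CC(=O)c3c(O)cc(OCc4cn(CCCO)nn4)cc3O2)cc1O`, has not yet been measured. It differs from compound 2 by 2-hydroxyethyl in place of phenyl on a saturated chain carbon bound to an aromatic nitrogen. Going by the values given here, no measured step makes this change; the nearest comparison, a benzyl in place of a cyclopentyl on the aromatic nitrogen, gave only a 1.0-fold higher number from compound 1 to compound 2 (0.02 log units; within the scatter), and the fluoro addition only a 1.5-fold lower number from compound 2 to compound 3 (0.18 log units; within the scatter). Since neither change at this position moved the number beyond the scatter, the expected step is no change at the digits printed from compound 2 to compound 4 (within the scatter). The value of compound 4 is estimated at 11000 nM, within a range of 4000 nM to 30000 nM.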

Compound 4, half-maximal inhibitory concentration: 16700 nM
Compound 4: middle estimate off by 1.5-fold (0.18 log units), on the low side, and the stated range covers the measured number.
By their numbers in this assay, from the lowest: compounds 3, 1, 2 and 4 (each within the scatter of the next, the first and the last beyond it).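

Replacing the benzyl ring with the open 3-hydroxypropyl chain adds a hydrogen-bond donor, yet this assay shows a 1.5-fold higher number from compound 2 to compound 4 (0.18 log units; within the scatter) as the result of this change. The comparison with cyclopentyl gives a 1.6-fold higher number from compound 1 to compound 4 (0.20 log units; within the scatter) and agrees, so a ring here is not required to stay within the scatter of compound 1 and compound 2. Only the 2-fluorobenzyl group opens a gap, with a 2.3-fold higher number from compound 3 to compound 4 (0.36 log units; beyond the scatter) as a modest step. Nothing available explains these numbers. From the compounds shown here alone, whether an amine, a carboxylic acid or a longer chain here would move the number further remains open.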